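Triazole nitrogen substituent and DU-145 inhibition

The source may hold more compounds than are shown below. What is called first, only, known or untested is meant among the compounds shown, and "the series" means these compounds.

Values in a functional assay on DU-145 cells (Homo sapiens) for inhibition, read by MTT assay, with a stated time of 24 h; on this read-out lower numbers stand for stronger inhibition and higher numbers for weaker inhibition:
compound 1, `CCOC(=O)C1=Cc2ccccc2OC1(OCc1cn(CC(=O)NC2CCCCC2)nn1)C(F)(F)F`, gives 10200 nM.
compound 2, `CCCCCCCCn1cc(COC2(C(F)(F)F)Oc3ccccc3C=C2C(=O)OCC)nn1`, sits at the assay limit > 150000 nM.
compound 3, `CCOC(=O)C1=Cc2ccccc2OC1(OCc1cn(-c2ccccc2)nn1)C(F)(F)F`, sits at the assay limit > 150000 nM.

Compound 3 therefore stands at the weak end of the series as a limit and not a number, and the limit of > 150000 nM in this assay, at which 2 of the 3 values shown sit, marks where it sits. Within the data shown here, compound 1 is the only member with a readable value.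

The change to compound 4, `CCOC(=O)C1=Cc2ccccc2OC1(OCc1cn(CC(=O)Nc2ccc(I)cc2Cl)nn1)C(F)(F)F`, is ((2-chloro-4-iodophenyl)carbamoyl)methyl in place of phenyl on an aromatic nitrogen. Among the measured compounds shown here, two measured steps bear on it. The step of an at least 14-fold higher number from compound 1 to compound 3 (1.16 log units; beyond the scatter) shows that removing the (cyclohexylcarbamoyl)methyl group in favour of phenyl on the aromatic nitrogen lost a large amount of inhibition; compound 4 reverses the direction of that step by reinstating a carbamoylmethyl group, here carrying a 2-chloro-4-iodophenyl amide in place of cyclohexyl. The step of an at least 14-fold higher number from compound 1 to compound 2 (1.16 log units; beyond the scatter) likewise shows that replacing the carbamoyl chain by a plain heptyl lost a large amount. For the measured compounds named here, no measured pair covers an aryl amide against a cyclohexyl amide, so the size of that part of the change is unknown.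

A large step toward stronger inhibition is expected, an at least 10-fold lower number from compound 3 to compound 4 (1.00 log units; beyond the scatter), with compound 4 estimated at 15000 nM, between 4000 nM and 60000 nM.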

Compound 4, half-maximal inhibitory concentration: 24400 nM
Beside the measured number, compound 4's estimate is 1.6-fold (0.21 log units) below it, within the range that was stated.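

In this assay, a second member with a carbamoylmethyl chain on the aromatic nitrogen gives a readable value, with an at least 6.1-fold lower number from compound 3 to compound 4 (0.78 log units; beyond the scatter) and an at least 6.1-fold lower number from compound 2 to compound 4 (0.78 log units; beyond the scatter), so readable inhibition in this series is no longer tied to the cyclohexyl amide. Among these compounds, the group on the amide nitrogen now has a measured effect of its own, as 2-chloro-4-iodophenyl in place of cyclohexyl gives a 2.4-fold higher number from compound 1 to compound 4 (0.38 log units; beyond the scatter), the only step here with numbers at both ends. Among the compounds shown, the two carbamoylmethyl amides give numbers, while compound 2 and compound 3, which lack that chain, each remain at an assay limit: the limit of > 150000 nM in this assay, at which 2 of the 4 values shown sit.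

The step between the two amides changes the ring and adds both halogens at once, so an unsubstituted phenyl amide or a ring carrying only chlorine or only iodine would be needed to separate those contributions. On these data alone, it also remains open whether the amide itself is required, which a simple ether, a primary amine or a carboxylic acid at the end of the chain would test, and whether a longer chain between the aromatic nitrogen and the amide carbonyl would be tolerated.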